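Removing the isopropyl group from compound 1

The compounds below may be only part of what the source reports. "The series", "measured", "known", "first", "only" and "open" are said of these compounds alone.

Measured so far:
compound 1 `CC(C)NCc1nnc(-c2ccccc2-c2ccccc2)s1` — 35 mg/kg
compound 2 `NCc1nnc(Cc2ccccc2)s1` — 200 mg/kg
compound 3 `CNCc1nnc(-c2ccccc2)s1` — > 200 mg/kg

In a functional assay on the whole organism with Mus musculus as the target (on this read-out higher numbers stand for an effect only at larger amounts of compound and lower numbers for an effect already at smaller amounts), compound 1 gives 35 mg/kg, the lowest of the two numbers shown; the nearest is compound 2 at 200 mg/kg, a gap beyond the scatter. Compound 3 reaches only a limit of this assay, (the limit of > 200 mg/kg in this assay, at which 1 of the 3 values shown sits), not a number. Compound 4 `NCc1nnc(-c2ccccc2-c2ccccc2)s1` has not yet been tested in this assay. It differs from compound 1 by hydrogen in place of isopropyl on an amine nitrogen. Among the compounds with values here, no measured pair shows this change alone. A step towards higher numbers in this assay is expected, as the unsubstituted amine in compound 2 sits at a high value, though its other part differs too. For compound 4 an estimate of 80 mg/kg is made, ranging from 30 mg/kg to 200 mg/kg, meaning an expected step of a 2.3-fold higher number from compound 1 to compound 4 (0.36 log units; beyond the scatter).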

Compound 4, dose for half-maximal effect: 22 mg/kg
Compound 4: middle estimate off by 3.6-fold (0.56 log units), on the high side, outside the stated range (below it).
By their numbers in this assay, from the lowest: compounds 4 and 1 (each within the scatter of the next); then compound 2.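

In this assay, hydrogen in place of isopropyl on this amine nitrogen gives a 1.6-fold lower number from compound 1 to compound 4 (0.20 log units; within the scatter). Within the data shown here, this is the first direct pair for this change, and it shows that, on the core of compound 1, the isopropyl group is not needed for an effect at these doses. Nothing shown gives a reason for this result. Going by these compounds, it remains open whether a larger group on this nitrogen, such as benzyl or cyclohexyl, would leave the number within the scatter. An acetyl group there is equally untested in the data shown.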